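The source may hold more compounds than are shown below. What is called first, only, known or untested is meant among the compounds shown, and "the series" means these compounds.

Measured compounds and their values in a toxicity assay on the whole organism (H4IIE cells) for cytotoxicity, with Rattus norvegicus as the target, read by MTT assay, with a stated time of 24 h, tested at 10 uM; on this read-out lower numbers stand for a stronger effect and higher numbers for a weaker effect at the one concentration tested:

compound 1 `Cc1ccc(C(C)C)c(OC(=O)Nc2ccc([N+](=O)[O-])cc2)c1`: 26.1%
compound 2 `Cc1ccc(C(C)C)cc1OC(=O)NC1CCCC1`: 37.4%

Among the measured compounds shown here, both compounds have been tested at a single concentration, and the number tells how much cell activity remains, so a smaller number means the compound hurt the cells more. Compound 2 stands at the top of the two numbers: its value of 37.4% is the higher of the pair, while compound 1 gives 26.1%, and the gap between the two is wider than the usual scatter of this kind of measurement. No direct comparison between these two compounds is given beyond their values, because they differ in more than one place.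

The next compound, compound 3 `Cc1ccc(C(C)C)cc1OC(=O)Nc1cccc(F)c1`, has not yet been measured in this assay. It is built from compound 2 by one change:

3-fluorophenyl in place of cyclopentyl on an amide-type nitrogen

For the measured compounds named here, there is no measured pair in this set that shows the same change, so the size of the step can only be guessed. A moderate step downward in this assay, meaning a somewhat stronger effect on the cells, is expected from compound 2 to compound 3, of about a number 7.4 percentage points lower from compound 2 to compound 3 (within the scatter). On that basis compound 3 is estimated to give 30%, with a likely range from 15% to 45%.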

Compound 3, a percentage reported as activity, at one concentration (the size of the read-out at that concentration, not a potency): 28.5%
Estimate against measurement, compound 3: 1.5 percentage points above, within the range that was stated.
By their numbers in this assay, from the lowest: compounds 1, 3 and 2 (each within the scatter of the next, the first and the last beyond it).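

Among the compounds shown here, exchanging cyclopentyl for 3-fluorophenyl on the amide-type nitrogen gives a number 8.9 percentage points lower from compound 2 to compound 3 (within the scatter) in this assay, and this is the first comparison here in which only one part of the molecule differs. This step lies within the usual scatter, so the measurement does not separate the two groups: at this position, a five-membered non-aromatic ring of carbon only and a six-membered aromatic ring carrying fluorine cannot be told apart at the one concentration tested. No measurement is available here that would explain this result, so it stands as an observation about these two compounds only.

The compounds shown leave open whether the ring and the fluorine would each make a difference on their own, a question that a plain phenyl group on the same nitrogen could help to answer when set against compound 3. They also leave open what an open chain such as n-butyl, or a phenyl ring carrying a carboxylic acid or an amine, would do at this position in this assay.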